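The source may hold more compounds than are shown below. What is called first, only, known or untested is meant among the compounds shown, and "the series" means these compounds.

Measured so far in an assay on cells for inhibition of HSP60/HSP10 (Homo sapiens), with a stated time of 60 min; on this read-out higher numbers stand for weaker inhibition and lower numbers for stronger inhibition:
- compound 1, `O=S(=O)(Nc1ccc(-c2nc3ccccc3o2)cc1)c1cccc(O)c1`: 62000 nM
- compound 2, `O=S(=O)(Nc1ccc(-c2nc3cc(NS(=O)(=O)c4cccc(O)c4)ccc3o2)cc1)c1cccc(O)c1`: 17000 nM
- compound 3, `COc1cccc(S(=O)(=O)Nc2ccc3oc(-c4ccccc4)nc3c2)c1`: > 100000 nM, which is a limit of the assay and not a number

Among the compounds with values here, compound 1 has the higher of the two plain numbers, and its one neighbour is reached by a 3.6-fold lower number from compound 1 to compound 2 (0.56 log units; beyond the scatter), a modest gain. Compound 3 differs from compound 1 in more than one place, so no single step can be read between them; all that its result shows is the limit of > 100000 nM in this assay, at which 1 of the 3 values shown sits.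

Compound 4, `Cc1cccc(S(=O)(=O)Nc2ccc(-c3nc4ccccc4o3)cc2)c1`, is not yet measured. It differs from compound 1 by methyl in place of hydroxy on an aromatic carbon. Within the data shown here, no measured step changes a group at this position: the one step recorded, from compound 1 to compound 2, adds a whole ((3-hydroxyphenyl)sulfonyl)amino group elsewhere, and compound 3 carries methoxy in a different overall arrangement. Compound 1 is already a weak inhibitor, and taking away the hydroxy is expected to cost a little rather than help, so the step of a 1.8-fold higher number from compound 1 to compound 4 (0.25 log units; within the scatter) is expected to be small and toward a higher number, with a real chance that only the limit is reported. Compound 4 is therefore estimated at 110000 nM, within 40000 nM to 300000 nM.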

Compound 4, half-maximal inhibitory concentration: > 100000 nM
Compound 4: no number, only a limit (the forecaster's own chance of this, stated with the estimate: 45%); the middle value is on the limit's open side.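

In this assay, compound 4 gives > 100000 nM, which is a limit of the assay and not a number. This is the first change shown at this position, 3-hydroxyphenyl to 3-methylphenyl, and it reads as an at least 1.6-fold higher number from compound 1 to compound 4 (0.20 log units; that floor lies within the scatter), so methyl in place of hydroxy brings no measurable gain, although the floor of this step is too small to prove a real loss. Methyl has no hydrogen-bond donor or acceptor, while the hydroxy it replaces has one of each, yet the result gives no number to set against compound 1 and only adds to the compounds that reach the limit: the limit of > 100000 nM in this assay, at which 2 of the 4 values shown sit.

The size of the step remains unknown, so the compounds shown cannot tell whether the hydroxy of compound 1 truly contributes to its inhibition or whether the two compounds differ only slightly. As far as these compounds go, it also remains open how an amine, a carboxylic acid or a fluorine in place of the hydroxy would read in this assay, and only such a group giving a plain number could begin to show what this position tolerates.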